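The source may report more compounds than this note shows. Statements on the series, on what has been measured and on what is new or still open speak of the compounds shown alone.

Measured so far:
- compound 1 `COc1ccc(CNC(=O)c2cc(-c3cc(C)cc(C)c3)cnc2-c2cccnc2)cc1`: 2980 nM
- compound 2 `COc1ccc(CNC(=O)c2cc(-c3cc(C)cc(C)c3)cnc2-c2cccnc2)cc1OC`: 462 nM

In an assay on isolated protein for displacement of a labelled ligand from Orexin/Hypocretin receptor type 1 (Homo sapiens), read by scintillation counting, with a stated time of 60 min (a lower number here means a stronger inhibitor, a higher number a weaker inhibitor), compound 2 holds the lower of the two numbers; its nearest neighbour is compound 1, and the step between them is a 6.5-fold lower number from compound 1 to compound 2 (0.81 log units; beyond the scatter), brought about by a methoxy in place of hydrogen on an aromatic carbon.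

Compound 3 `COc1ccc(CNC(=O)c2cc(-c3cc(F)cc(F)c3)cnc2-c2cccnc2)cc1OC` carries a different change: 3,5-difluorophenyl in place of 3,5-dimethylphenyl on an aromatic carbon. For the measured compounds named here, the one measured step concerns the methoxy on the other aromatic ring and does not touch the ring that is altered here, so there is no measured step that bears directly on this exchange. With nothing to anchor it, a step within the scatter or a modest one in either direction is the plain expectation, with a wide range to match.

Compound 3 is therefore expected to give about 800 nM in this assay, within a range of 200 nM to 3000 nM. The expected step is a 1.7-fold higher number from compound 2 to compound 3 (0.24 log units; within the scatter).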

Compound 3, inhibition constant: 5150 nM
Compound 3: middle estimate off by 6.4-fold (0.81 log units), on the low side; measured number outside the range, above it.
By their numbers in this assay, from the lowest: compound 2; then compounds 1 and 3 (each within the scatter of the next).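

In this assay, for the compounds shown here, the position para to a pyridin-3-yl group proves sensitive to its aromatic substituent: 3,5-difluorophenyl in place of 3,5-dimethylphenyl gives an 11-fold higher number from compound 2 to compound 3 (1.05 log units; beyond the scatter), a large step beyond the scatter, whereas the only earlier step, at the other aromatic ring, was modest at a 6.5-fold lower number from compound 1 to compound 2 (0.81 log units; beyond the scatter). The two groups match in heavy atoms, in their single six-membered aromatic ring of carbon only, and in their hydrogen-bond donor and acceptor counts, so these counts do not separate them, and the step goes with the exchange of the two methyl groups for two fluorines. No measurement on hand accounts for the loss in binding.

On these data alone, it remains open whether the step follows from having two fluorines or from losing two methyl groups, which a 3-fluoro-5-methylphenyl, 3,5-dichlorophenyl or unsubstituted phenyl group at this position would help separate. As far as these compounds go, it is also open whether the step seen with the added methoxy group would keep its size with 3,5-difluorophenyl in place, and whether larger groups such as 3,5-dimethoxyphenyl would be accepted here.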